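This account rests on a few compounds, and the source may have more. Where it says the series, first, only, none or still open, it means among the compounds named here.

Measured compounds:
- compound 1, `COc1cccc(CNC(=O)c2cn(CCN(C)C)c3cc(-c4cn[nH]c4)ccc23)c1`: 0.333 h
- compound 2, `COc1cccc(CNC(=O)c2[nH]c3nc(-c4cn[nH]c4)ccc3c2CN2CCN(C)CC2)c1`: 0.0167 h
- compound 3, `COc1cccc(CN(C)C(=O)c2cc3ccc(-c4cn[nH]c4)nc3[nH]2)c1`: 0.4 h

Of the compounds shown here, three have been tested in an in vitro ADME assay on microsomes from liver (Homo sapiens) for metabolic stability; on this read-out higher numbers stand for a longer-lived compound and lower numbers for a shorter-lived compound. Compound 1 gives 0.333 h, the second highest of the three numbers. Its nearest neighbour is compound 3, which gives 0.4 h; the two numbers lie within the usual scatter of this assay, so no order between them can be read. The furthest is compound 2, which gives 0.0167 h, a much lower number that lies well beyond the scatter. Among the measured compounds shown here, no two of the measured compounds differ in one place only, so no single step on the shared core has been isolated so far.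

The unmeasured compound 4, `COc1cccc(CNC(=O)c2cn(-c3ccccc3)c3cc(-c4cn[nH]c4)ccc23)c1`, is the closest relative of compound 1. The change is phenyl in place of 2-(dimethylamino)ethyl on an aromatic nitrogen. Nothing in the measured set speaks directly to such a change, so the expectation for compound 4 rests on compound 1 alone and is held loosely. The step from compound 1 to compound 4 in this assay is estimated as a 1.2-fold higher number from compound 1 to compound 4 (0.08 log units; within the scatter), which is expected to stay within the scatter rather than to move clearly in either direction. Compound 4 is therefore estimated at 0.4 h, with a range from 0.15 h to 1 h.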

Compound 4, half-life: 0.167 h
Beside the measured number, compound 4's estimate is 2.4-fold (0.38 log units) above it; the range from low to high includes it.
By their numbers in this assay, from the lowest: compound 2; then compounds 4, 1 and 3 (each within the scatter of the next, the first and the last beyond it).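

In this assay, among the compounds shown here, putting phenyl in place of 2-(dimethylamino)ethyl on an aromatic nitrogen gives a 2.0-fold lower number from compound 1 to compound 4 (0.30 log units; within the scatter) and is the first step that can be read in one place alone. The two compounds therefore cannot be put in order: at this position of the core, a chain carrying a dimethylamino end and a six-membered aromatic ring of carbon only are not told apart by this read-out, so the chain's nitrogen is not shown to matter for the half-life here, and neither is the ring. No measurement at hand offers an explanation for this result.

Going by these compounds, whether other groups on the same aromatic nitrogen, such as a morpholine ring, a pyridine ring, a carboxylic acid on a short chain or a longer chain ending in an amine, would give a number beyond the scatter from compound 1 remains open. Also open is what lies behind the low number of compound 2 at 0.0167 h, which no step in one place yet links to any other compound shown.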